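Replacing a methyl on the side-chain oxygen: effect on solubility

The source may hold more compounds than are shown below. What is called first, only, known or untested is meant among the compounds shown, and "the series" means these compounds.

Measured compounds:
compound 1 `COc1cc(/C=C/C(=O)/C=C(/C=C/c2ccc(O)c(OC)c2)NCCO)ccc1O`: 8140 nM
compound 2 `COCCNC(=C\C(=O)/C=C/c1ccc(O)cc1)/C=C/c1ccc(O)cc1`: 37500 nM
compound 3 `COCCNC(=C\C(=O)/C=C/c1ccc(O)c(OC)c1)/C=C/c1ccc(O)c(OC)c1`: 16700 nM

All three were tested in a physicochemical assay for solubility, using the shake flask method, in phosphate buffer, with a stated time of 90 min, at pH 6.8; on this read-out higher numbers stand for higher solubility and lower numbers for lower solubility. Compound 2 shows the highest number of the three, and the difference between the core of compound 2 and the core of compound 3 is not broken down here. From compound 3 to compound 1 the change is hydrogen in place of methyl on an oxygen on a saturated carbon and the step was a 2.1-fold lower number from compound 3 to compound 1 (0.31 log units; beyond the scatter).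

Compound 4 `O=C(/C=C(/C=C/c1ccc(O)cc1)NCCO)/C=C/c1ccc(O)cc1` has not yet been measured in this assay. It differs from compound 2 by hydrogen in place of methyl on an oxygen on a saturated carbon at the same place, so this is the same change. Because the earlier step was a 2.1-fold lower number from compound 3 to compound 1 (0.31 log units; beyond the scatter), a step of similar size is expected from compound 2 to compound 4, namely a 2.1-fold lower number from compound 2 to compound 4 (0.32 log units; beyond the scatter). Compound 4 is therefore estimated at 18000 nM, most likely between 8000 nM and 40000 nM.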

Compound 4, solubility: 38700 nM
Compound 4: the middle estimate sits 2.2-fold (0.33 log units) below what was measured, within the range that was stated.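

In this assay the change from 2-methoxyethyl to 2-hydroxyethyl gave a 2.1-fold lower number from compound 3 to compound 1 (0.31 log units; beyond the scatter) on one core but a 1.0-fold higher number from compound 2 to compound 4 (0.01 log units; within the scatter) on the other, so the step seen on the first core did not carry over to the second. This shows that a step measured on one core cannot simply be assumed on a related core in this series, although one pair per core cannot show how the two cores generally compare. Nothing given here explains why the two pairs differ.

Still open, as far as these compounds go, is how the two cores would compare with a longer chain such as 3-hydroxypropyl in place of 2-hydroxyethyl. The same question applies to a chain ending in an amine or a carboxylic acid.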